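The compounds below may be only part of what the source reports. "The series", "measured", "known", "first", "only" and "open" are said of these compounds alone.

Compound 2 `COc1ccccc1Cc1cc2c(N)nc(-c3nc(C)cs3)nc2s1` gives 186 nM in a functional assay on CHO-K1 cells for antagonist activity at adenosine receptor A1 (Homo sapiens), read by a beta-galactosidase reporter and cAMP accumulation, with stated times of 15 min and 6 h; a lower number here means a stronger inhibitor, a higher number a weaker inhibitor. Within the data shown here, compound 3 `Cc1csc(-c2nc(N)c3cc(Cc4ccccc4Cl)sc3n2)n1` gives 49.6 nM in this assay, the lowest of the two numbers known so far; the only measured step, a 3.8-fold lower number from compound 2 to compound 3 (0.57 log units; beyond the scatter), is what sets it apart. Compound 1 `Cc1ccc(-c2nc(N)c3cc(Cc4ccccc4F)sc3n2)o1` returns in this assay not a number but a limit, < 16 nM, and (the limit of < 16 nM in this assay, at which 1 of the 3 values shown sits). Compound 4 `Cc1csc(-c2nc(N)c3cc(Cc4ccccc4F)sc3n2)n1` differs from compound 3 by fluoro in place of chloro on an aromatic carbon. Among the measured compounds shown here, no measured step covers this exchange, and the one recorded step, a 3.8-fold lower number from compound 2 to compound 3 (0.57 log units; beyond the scatter), concerns a different group, so it offers only indirect guidance. Compound 4 is therefore expected to show a 1.7-fold lower number from compound 3 to compound 4 (0.22 log units; within the scatter) in this assay, a move no larger than the scatter, and is estimated at 30 nM, most likely between 10 nM and 90 nM.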

Compound 4, inhibition constant: 28.6 nM
For compound 4 the middle estimate is 1.0-fold (0.02 log units) above the measured one; measured number inside the range.
By their numbers in this assay, from the lowest: compounds 4 and 3 (each within the scatter of the next); then compound 2. At a limit, below all of these: compound 1.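

Exchanging 2-chlorobenzyl for 2-fluorobenzyl gives, in this assay, a 1.7-fold lower number from compound 3 to compound 4 (0.24 log units; within the scatter), so the two halogens cannot be told apart at this place, whereas methoxy stands apart from fluoro as it did from chloro: a 6.5-fold lower number from compound 2 to compound 4 (0.81 log units; beyond the scatter). Exchanging 5-methylfuran-2-yl for 4-methyl-1,3-thiazol-2-yl gives an at least 1.7-fold higher number from compound 1 to compound 4 (0.25 log units; that floor lies within the scatter), a step that rests on a limit and so shows no firm difference: the limit of < 16 nM in this assay, at which 1 of the 4 values shown sits.

As far as these compounds go, whether an amine or a hydroxyl at this place would track the halogens or methoxy remains open. From the compounds shown here alone, the true number of compound 1 also remains open.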